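The compounds below may be only part of what the source reports. "The series", "measured", "known", "first", "only" and "open" are said of these compounds alone.

Compound 1 `CC(=O)O[C@]12C=CC(=O)C[C@H]1OCC2` gives 0.5 ug/mL in a functional assay on P388 cells (Mus musculus) for cytotoxicity; on this read-out lower numbers stand for stronger inhibition and higher numbers for weaker inhibition. Compound 2 `CCCC(=O)O[C@]12C=CC(=O)C[C@H]1OCC2` gives 0.6 ug/mL in this assay, and compound 3 `CCCCCC(=O)O[C@]12C=CC(=O)C[C@H]1OCC2` gives 0.3 ug/mL in this assay. The three share one core and differ only in the length of the saturated chain bound to the carbonyl carbon. Compound 3 holds the lowest of the three numbers, yet its step from compound 1, a 1.7-fold lower number from compound 1 to compound 3 (0.22 log units; within the scatter), and its step from compound 2, a 2.0-fold lower number from compound 2 to compound 3 (0.30 log units; within the scatter), both stay within the scatter, so the three compounds cannot be told apart on this read-out.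

Compound 4 `CCCCCCCC(=O)O[C@]12C=CC(=O)C[C@H]1OCC2` carries the change (ethyl in place of hydrogen on a saturated chain carbon, five bonds along the chain from a carbonyl carbon). Among the measured compounds shown here, two measured steps bear on this kind of change: a 1.2-fold higher number from compound 1 to compound 2 (0.08 log units; within the scatter) and a 2.0-fold lower number from compound 2 to compound 3 (0.30 log units; within the scatter). Each of them added an ethyl group further along the chain, each remained within the scatter, and the two did not even agree in direction. On that basis no step beyond the scatter is expected in this assay on going from compound 3 to compound 4, in either direction. Compound 4 is therefore expected to give about 0.35 ug/mL in this assay, within a range from 0.15 ug/mL to 0.8 ug/mL, which corresponds to an expected step of a 1.2-fold higher number from compound 3 to compound 4 (0.07 log units; within the scatter).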

Compound 4, half-maximal inhibitory concentration: 0.3 ug/mL
Compound 4: middle estimate off by 1.2-fold (0.07 log units), on the high side, within the range that was stated.
By their numbers in this assay, from the lowest: compounds 3, 4, 1 and 2 (each within the scatter of the next).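

Five bonds along the chain from a carbonyl carbon, ethyl in place of hydrogen leaves the number in this assay within the scatter (no change at the digits printed from compound 3 to compound 4 (within the scatter)), and the longer changes that end at compound 4 stay within it as well (a 2.0-fold lower number from compound 2 to compound 4 (0.30 log units; within the scatter); a 1.7-fold lower number from compound 1 to compound 4 (0.22 log units; within the scatter)). Among the compounds shown here, what the earlier compounds did not show is that even hexyl in place of hydrogen on the saturated chain carbon bound to a carbonyl carbon produces no step beyond the scatter, and that the ethyl change reads alike at a second place on the chain: the same change on two cores in this assay, a 1.2-fold higher number (0.08 log units; within the scatter) from compound 1 to compound 2 and no change at the digits printed (within the scatter) from compound 3 to compound 4, 1.2-fold (0.08 log units) apart, within the scatter of two such steps. The butyl change likewise gives steps that cannot be told apart when it is read at two places on the chain: the same change on two cores in this assay, a 1.7-fold lower number (0.22 log units; within the scatter) from compound 1 to compound 3 and a 2.0-fold lower number (0.30 log units; within the scatter) from compound 2 to compound 4, 1.2-fold (0.08 log units) apart, within the scatter of two such steps.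

All four compounds carry plain saturated chains and lie within the scatter of one another, so the series offers no step beyond the scatter against which a trend in chain length could be read. On these data alone, whether a longer chain, or a chain bearing an amine or a carboxylic acid, would move the number beyond the scatter stays open.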